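Chloro to Nitro on a Nucleoside Thioether Inhibitor

The source may hold more compounds than are shown below. What is called first, only, known or untested is meant among the compounds shown, and "the series" means these compounds.

Compound 1, `OC[C@H]1O[C@@H](n2cnc3c(SCc4ccccc4Cl)ncnc32)[C@H](O)[C@@H]1O`, gives 117 nM in an assay on isolated protein for inhibition of Equilibrative nucleoside transporter 1 (Homo sapiens); on this read-out lower numbers stand for stronger inhibition and higher numbers for weaker inhibition. Compound 2, `OC[C@H]1O[C@@H](n2cnc3c(SCc4cccc(Cl)c4)ncnc32)[C@H](O)[C@@H]1O`, gives 18.2 nM. Compound 3, `N#Cc1ccccc1CSc1ncnc2c1ncn2[C@@H]1O[C@H](CO)[C@@H](O)[C@H]1O`, gives 38.9 nM.

Compound 2 stands lowest of the three; the gaps to it are a 6.4-fold lower number from compound 1 to compound 2 (0.81 log units; beyond the scatter) and a 2.1-fold higher number from compound 2 to compound 3 (0.33 log units; beyond the scatter). Compound 4, `O=[N+]([O-])c1cccc(CSc2ncnc3c2ncn3[C@@H]2O[C@H](CO)[C@@H](O)[C@H]2O)c1`, is not yet measured and differs from compound 2 by nitro in place of chloro on an aromatic carbon. Within the data shown here, the only measured replacement of chloro is a 3.0-fold lower number from compound 1 to compound 3 (0.48 log units; beyond the scatter), and that swap sat at another spot and used cyano, so no measured step covers nitro. The expectation for compound 4 is therefore a modest step of uncertain direction, a 1.4-fold higher number from compound 2 to compound 4 (0.14 log units; within the scatter). Compound 4 is estimated at 25 nM, within 8 nM to 75 nM.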

Compound 4, inhibition constant: 1.78 nM
Beside the measured number, compound 4's estimate is 14-fold (1.15 log units) above it, and the stated range ends above it.
By their numbers in this assay, from the lowest: compound 4; then compound 2; then compound 3; then compound 1.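

Nitro in place of chloro on this aromatic carbon gives a 10-fold lower number from compound 2 to compound 4 (1.01 log units; beyond the scatter) in this assay, a large step where every earlier step was modest, so the group held here can matter far more than those steps showed. The 3-nitrophenyl group also stands well clear of the other two aryl groups, with a 22-fold lower number from compound 3 to compound 4 (1.34 log units; beyond the scatter) and a 66-fold lower number from compound 1 to compound 4 (1.82 log units; beyond the scatter). No measurement here bears on why nitro does this.

Still open, as far as these compounds go, is whether an amine or a carboxylic acid on this same carbon would keep the gain. Also open, from the compounds shown here alone, is how nitro would fare on another carbon of the ring.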